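The source may report more compounds than this note shows. Statements on the series, on what has been measured and on what is new or still open speak of the compounds shown alone.

Measured compounds in an in vitro assay on CHOK cells for displacement of a labelled ligand from growth hormone secretagogue receptor type 1 (Homo sapiens); on this read-out higher numbers stand for weaker inhibition and lower numbers for stronger inhibition:
compound 1 `CCc1nc(N)nc(N)c1-c1ccc(NCc2ccc(C(C)=O)cc2)cc1` gives 57 nM
compound 2 `CCc1nc(N)nc(N)c1-c1ccc(NCc2ccnc(Cl)c2)cc1` gives 110 nM

Compound 1 stands together with compound 2 within the scatter: the step of a 1.9-fold higher number from compound 1 to compound 2 (0.29 log units; within the scatter) does not separate them. For the measured compounds named here, that step exchanges the aryl group on the saturated chain carbon bound to the ring nitrogen; it is the only measured step in the set.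

Compound 3 `CC(=O)c1ccc(CNc2ccc(-c3c(N)nc(N)nc3COCc3ccccc3)cc2)cc1` is not yet measured. It differs from compound 1 by benzyloxy in place of methyl on a saturated chain carbon bound to an aromatic carbon. Going by the values given here, no measured step touches the ethyl group on the shared core, so the step from compound 2 gives no direct guide; the single measured exchange elsewhere on compound 1 left the number within the scatter, which is all that can be drawn on. The expectation for compound 3 is therefore a modest step, if any, in this assay, on the weaker side, as a 1.6-fold higher number from compound 1 to compound 3 (0.20 log units; within the scatter). Compound 3 is estimated at 90 nM, with a range from 25 nM to 320 nM.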

Compound 3, half-maximal inhibitory concentration: 1.2 nM
For compound 3 the middle estimate is 75-fold (1.88 log units) above the measured one; the whole stated range lies above it.
By their numbers in this assay, from the lowest: compound 3; then compounds 1 and 2 (each within the scatter of the next).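

In this assay, for the compounds shown here, the step of benzyloxy in place of methyl on a saturated chain carbon bound to an aromatic carbon is a 48-fold lower number from compound 1 to compound 3 (1.68 log units; beyond the scatter) and so marks this place as far more responsive than the aryl group exchange, the only earlier step, which stayed within the scatter. The change from ethyl to (benzyloxy)methyl brings in one six-membered aromatic ring of carbon only and 1 hydrogen-bond acceptor, the first such change at this place among the compounds shown. No evidence at hand bears on why the number falls so far.

The ring and the oxygen enter together, so their separate shares cannot be read from these compounds. Also open, from the compounds shown here alone, is how a methoxymethyl group, a phenethyl chain or an aminomethyl group would read at this place, and whether the same change on compound 2, with its 2-chloropyridin-4-yl group, would give a similar step.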